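The source may hold more compounds than are shown below. What is called first, only, known or untested is meant among the compounds shown, and "the series" means these compounds.

Values in an ADME assay on TERT-RPE1 cells (Homo sapiens) for cytotoxicity, read by MTT assay, with a stated time of 72 h; on this read-out higher numbers stand for weaker inhibition and lower numbers for stronger inhibition:
Compound 1 `C=CC/N=C1\S/C(=C\c2ccc(OC)cc2)C(=O)N1C`: > 100000 nM (a limit)
Compound 2 `COc1ccc(/C=C2\S/C(=N\c3ccc(C(C)(C)C)cc3)N(C)C2=O)cc1`: 46700 nM
Compound 3 `COc1ccc(/C=C2\S/C(=N\c3ccc(C)cc3)N(C)C2=O)cc1`: > 100000 nM (a limit)

Compound 3 yields no number, standing at the limit of > 100000 nM in this assay, at which 2 of the 3 values shown sit. Compound 4 `COc1ccc(/C=C2\S/C(=N\c3ccc(OC)cc3)N(C)C2=O)cc1` has methoxy in place of methyl on an aromatic carbon, para to a large group: methoxy in place of methyl on an aromatic carbon. The nearest measured change is an at least 2.1-fold higher number from compound 2 to compound 3 (0.33 log units; beyond the scatter), made on an aromatic carbon as well. The other step, a step that the two limits leave unreadable from compound 1 to compound 3, gives no size. In this assay, no step beyond the scatter is therefore expected, and any readable shift would be expected toward lower numbers. The expected step is a number no higher from compound 3 to compound 4 (the limit leaves the size open). The estimate for compound 4 is 100000 nM, with an expected range of 45000 nM to 200000 nM.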

Compound 4, half-maximal inhibitory concentration: > 100000 nM
Compound 4 ended at the assay's limit; the forecaster's own chance of this, stated with the estimate: 75%; the middle value sits exactly at the limit.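

In this assay, replacing the tert-butyl group with methoxy gives an at least 2.1-fold higher number from compound 2 to compound 4 (0.33 log units; beyond the scatter), so methoxy joins methyl as a second group at this place that leaves the number higher than tert-butyl does. Compound 4 gives > 100000 nM, which is a limit. The steps among compound 1, compound 3 and compound 4 cannot be read, so methoxy and methyl stay unseparated and tert-butyl remains the only group here with a number: the limit of > 100000 nM in this assay, at which 3 of the 4 values shown sit.

On these data alone, what an amine, a carboxylic acid or a longer chain at this place would give stays open. The true values of compound 3 and compound 4 also stay hidden.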